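From pyrrolidin-1-yl to methyl on the chain of compound 2

A few compounds are considered here, and "the series" means these few. Any claim that something is new, unique, unknown or untested is made for them only; others in the source may bear on it.

Compound 1 `CCn1c(N)c(-c2nc3ccccc3[nH]2)c2nc(C#N)c(C#N)nc21` | > 50000 nM
Compound 2 `N#Cc1nc2c(-c3nc4ccccc4[nH]3)c(N)n(CCN3CCCC3)c2nc1C#N` | > 50000 nM
Compound 3 `CCCn1c(N)c(-c2nc3ccccc3[nH]2)c2nc(C#N)c(C#N)nc21` | not yet measured

In a functional assay on A549 cells (Homo sapiens) for antiproliferative activity, read by MTT assay, with a stated time of 48 h (a lower number here means a stronger inhibitor, a higher number a weaker inhibitor), compound 2 gives > 50000 nM as a limit, not a number. Compound 1 also gives a limit, > 50000 nM in the same read-out. Both compounds stand at the limit of > 50000 nM in this assay, at which 2 of the 2 values shown sit, and neither has a number.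

Compound 3 carries methyl in place of pyrrolidin-1-yl on a saturated chain carbon, two bonds along the chain from an aromatic nitrogen, so that 2-(pyrrolidin-1-yl)ethyl becomes propyl. For the measured compounds named here, the one measured step at that carbon is a step that the two limits leave unreadable from compound 1 to compound 2 for the same group, and it offers no size to carry over. In this assay the expected step is a number no higher from compound 2 to compound 3 (the limit leaves the size open) in this account, with none beyond the scatter foreseen in either direction. The estimate for compound 3 is 50000 nM with an expected range from 25000 nM to 100000 nM in all, most likely reported again as a limit.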

Compound 3, half-maximal inhibitory concentration: 1970 nM
Beside the measured number, compound 3's estimate is 25-fold (1.40 log units) above it; measured number below the stated range.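

In this assay, this position proves able to move the read-out: methyl in place of pyrrolidin-1-yl gives an at least 25-fold lower number from compound 2 to compound 3 (1.40 log units; beyond the scatter), and methyl in place of hydrogen at the same carbon gives an at least 25-fold lower number from compound 1 to compound 3 (1.40 log units; beyond the scatter). Compound 3 thus shows that a change of one methyl on this chain can separate a measured number from a limit, whichever of the two earlier groups it replaces. The step from compound 1 to compound 2 cannot be read, and the values of both compounds are limits, not numbers: the limit of > 50000 nM in this assay, at which 2 of the 3 values shown sit.

The compounds shown leave open whether the number keeps falling with a longer chain such as butyl, or changes with a branched one such as isopropyl. They also leave open whether another amine at the chain end, such as morpholine or dimethylamino, would give a number in this read-out.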